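Fluoromethyl-substituted carbamate replaces tert-butyl on compound 2

The compounds below may be only part of what the source reports. "The series", "measured", "known", "first", "only" and "open" are said of these compounds alone.

Compound 1 `CC(C)(C)OC(=O)N1CCC(O[C@H]2CC[C@H](Oc3ccc(S(C)(=O)=O)cc3)CC2)CC1` and compound 2 `CC(C)(C)OC(=O)N1CCC(O[C@H]2CC[C@H](Oc3cnc(S(C)(=O)=O)cn3)CC2)CC1` share the same core and differ only in the aryl group. In a functional assay on isolated protein for agonist activity at Glucose-dependent insulinotropic receptor (Homo sapiens), read by HTRF and cAMP accumulation (on this read-out higher numbers stand for an effect only at larger amounts of compound and lower numbers for an effect already at smaller amounts), compound 1 gives 16.1 nM, and in this assay compound 2 gives 5.9 nM. Among the compounds with values here, the change a 2.7-fold lower number from compound 1 to compound 2 (0.44 log units; beyond the scatter) was a modest step beyond the scatter, and compound 2 holds the lowest of the two numbers measured so far, with compound 1 as its only neighbour.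

Compound 3 `C[C@@H](CF)OC(=O)N1CCC(O[C@H]2CC[C@H](Oc3cnc(S(C)(=O)=O)cn3)CC2)CC1` is not yet measured. It differs from compound 2 by 1-(fluoromethyl)ethyl in place of tert-butyl on an oxygen next to a carbonyl group. Within the data shown here, no measured step touches this position: the single step from compound 1 to compound 2 concerns the aryl group and says nothing about the carbamate side. There is therefore no basis for expecting a step beyond the scatter in this assay in either direction. The estimate for compound 3 is 6.5 nM, with a range from 2 nM to 20 nM, which corresponds to an expected step of a 1.1-fold higher number from compound 2 to compound 3 (0.04 log units; within the scatter).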

Compound 3, half-maximal effective concentration: 31.1 nM
The estimate for compound 3 lay 4.8-fold (0.68 log units) below the measured number; measured number outside the range, above it.
By their numbers in this assay, from the lowest: compound 2; then compounds 1 and 3 (each within the scatter of the next).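

In this assay, the carbamate side turns out to matter: with 1-(fluoromethyl)ethyl in place of tert-butyl on an oxygen next to a carbonyl group, the result is a 5.3-fold higher number from compound 2 to compound 3 (0.72 log units; beyond the scatter). Within the data shown here, the earlier step concerned only the aryl group, so this is the first reading at this position, and it shows that a swap between two groups of equal heavy-atom count, both without a ring, hydrogen-bond donors or acceptors, or net charge, can still move the number beyond the scatter. Nothing measured here accounts for the step, which remains an observation without an explanation.

The entering group differs from tert-butyl both in carrying a fluorine and in having a defined stereocentre, and the compounds shown do not tell these two features apart; a plain isopropyl group or the opposite stereoisomer of 1-(fluoromethyl)ethyl on the same oxygen would address that question. Also open, as far as these compounds go, is whether the same change would have a similar effect with 4-(methylsulfonyl)phenyl in place of 5-(methylsulfonyl)pyrazin-2-yl.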